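Ethoxy to tert-butyl on the aryl of compound 1

This account rests on a few compounds, and the source may have more. Where it says the series, first, only, none or still open, it means among the compounds named here.

Working notes on a small solubility set around a shared core. Compound 1 `CCOc1ccc(NC(=O)Nc2ccc(OC[C@@]3(C)Cn4cc([N+](=O)[O-])nc4O3)cc2)cc1` carries an ethoxy group on its outer aryl ring; in a physicochemical assay for solubility, read by HPLC, with a stated time of 4 h, at pH 7 (on this read-out lower numbers stand for lower solubility and higher numbers for higher solubility), compound 1 gives 6.66 ug/mL. Among the compounds with values here, this is the only numerical value in hand for the set. Within the data shown here, compound 2 `COc1ccc(S(=O)(=O)N2CCN(c3ccc(OC[C@@]4(C)Cn5cc([N+](=O)[O-])nc5O4)cc3)CC2)cc1` differs from compound 1 in more than one place, so no single step is drawn between them. In this assay compound 2 is reported only as a limit, < 1 ug/mL, not as a number; of the two values shown, one sits at that limit (the limit of < 1 ug/mL in this assay, at which 1 of the 2 values shown sits).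

Compound 3 `CC(C)(C)c1ccc(NC(=O)Nc2ccc(OC[C@@]3(C)Cn4cc([N+](=O)[O-])nc4O3)cc2)cc1` is the pair to compound 1, with one change: tert-butyl in place of ethoxy on an aromatic carbon. No measured step of this kind is shown, so any expectation rests on compound 1 alone. The step from compound 1 to compound 3 is expected as a moderate fall, a 3.3-fold lower number from compound 1 to compound 3 (0.52 log units; beyond the scatter), beyond the usual scatter but uncertain in size. Compound 3 is therefore estimated at 2 ug/mL, with a likely range of 0.6 ug/mL to 6 ug/mL, and some chance that this assay returns only a limit for it.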

Compound 3, solubility: < 1 ug/mL
Compound 3 ended at the assay's limit (the forecaster's own chance of this, stated with the estimate: 30%); middle value at least 2.0-fold (0.30 log units) from the limit.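

Within the data shown here, this is the first step in the set that can be read at a single place: on an aromatic carbon para to a large group, tert-butyl in place of ethoxy gives an at least 6.6-fold lower number from compound 1 to compound 3 (0.82 log units; beyond the scatter) in this assay. Compound 3 is reported only as a limit, < 1 ug/mL, not as a number, so this step has a lower bound and no measured size. The read-out therefore offers little room to separate further changes at this position, and any outcome at the limit would remain unresolved: the limit of < 1 ug/mL in this assay, at which 2 of the 3 values shown sit.

The compounds shown leave open whether another group at this position, such as a dimethylamino group, a carboxylic acid or a longer alkoxy chain, would give a number clearly above that of compound 1, which gives 6.66 ug/mL. They also leave open whether the step follows the loss of the ether oxygen or the arrival of the branched tert-butyl carbons, a question that an isopropyl or a propyl group at the same place could help to separate.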